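Removing one trifluoromethyl from a diaryl urea pyrazole

The source may report more compounds than this note shows. Statements on the series, on what has been measured and on what is new or still open speak of the compounds shown alone.

Two pyrazole ureas have been tested so far. Compound 1 `O=C(Nc1cccc(-n2cc(-c3ccncc3)c(-c3cc(O)cc(Cl)c3)n2)c1)Nc1ccc(Cl)c(C(F)(F)F)c1` carries a hydroxy group on one aryl ring and a single trifluoromethyl beside a chlorine on the urea's distal ring. Compound 2 `COc1cc(Cl)cc(-c2nn(-c3cccc(NC(=O)Nc4cc(C(F)(F)F)cc(C(F)(F)F)c4)c3)cc2-c2ccncc2)c1` carries a methoxy group instead and two trifluoromethyl groups on that distal ring. In a functional assay on MCF7 cells (Homo sapiens) for inhibition, read by sulforhodamine B assay, with a stated time of 48 h, tested at 100 uM (a higher number here means a weaker effect of the compound at the concentration tested, a lower number a stronger effect), compound 1 gives -43%, and in this assay compound 2 gives -44%. Of the two numbers, that of compound 2 sits together with that of compound 1, the pair lying within the scatter of each other, so nothing separates them.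

Compound 3 `COc1cc(Cl)cc(-c2nn(-c3cccc(NC(=O)Nc4cccc(C(F)(F)F)c4)c3)cc2-c2ccncc2)c1` has not been measured yet. It differs from compound 2 in one place: hydrogen in place of trifluoromethyl on an aromatic carbon. The methoxy group, the chlorine and the remaining trifluoromethyl are unchanged.

Within the data shown here, no step between measured compounds is available to calibrate this change. Since compound 1 and compound 2 give the same reading with different substitution on this ring, the loss of one trifluoromethyl is expected to move this assay little, if at all, beyond the scatter. The step from compound 2 to compound 3 is estimated at a number 9 percentage points higher from compound 2 to compound 3 (within the scatter). For compound 3 the expected value is -35%, in the range -60% to 0%.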

Compound 3, a percentage reported as activity, at one concentration (the size of the read-out at that concentration, not a potency): -24%
Compound 3: middle estimate off by 11 percentage points, on the low side; the range from low to high includes it.
By their numbers in this assay, from the lowest: compounds 2 and 1 (each within the scatter of the next); then compound 3.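

The two earlier compounds differed in more than one place, so their shared reading could not isolate this carbon; the pair compound 2 and compound 3 differs only here, and it shows that the position is not indifferent to the change. In this assay, replacing trifluoromethyl with hydrogen on this aromatic carbon gives a number 20 percentage points higher from compound 2 to compound 3 (beyond the scatter) and so leaves a weaker effect at the concentration tested, although a clear effect remains with the other trifluoromethyl still in place. No measurement at hand accounts for this shift, and the reason for it stays unknown.

From the compounds shown here alone, whether a methyl group, a chlorine or a nitrile on this same aromatic carbon would keep the reading of compound 2 or fall to that of compound 3 remains open, so it cannot yet be said whether trifluoromethyl itself matters or any group larger than hydrogen would do. Also open, going by these compounds, is whether the step keeps its size with a hydroxy group in place of the methoxy group, and whether it would hold in a true potency measurement rather than a reading at one concentration.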